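The source may report more compounds than this note shows. Statements on the series, on what has been measured and on what is new or still open speak of the compounds shown alone.

Measured in a functional assay on HeLa cells (Homo sapiens) for cytotoxicity, read by cell counting, with a stated time of 48 h; on this read-out lower numbers stand for an effect already at smaller amounts and higher numbers for an effect only at larger amounts of compound:
compound 1 `CCCCCCCCCC(=O)O[C@H]1[C@H](O)[C@H](n2ccc(N)nc2=O)O[C@@H]1CO`: 0.09 ug/mL
compound 2 `CCCCCCCCCCCCCCCCCCCCCC(=O)OC[C@H]1O[C@@H](n2ccc(N)nc2=O)[C@@H](O)[C@@H]1O`: 0.04 ug/mL
compound 3 `CCCCCCCCCC(=O)OC[C@H]1O[C@@H](n2ccc(N)nc2=O)[C@@H](O)[C@@H]1OC(=O)CCCCCCCCC`: 0.11 ug/mL

Compound 1 stands second highest of the three numbers. Nearest to it is compound 3, reached by a 1.2-fold higher number from compound 1 to compound 3 (0.09 log units; within the scatter), with nonylcarbonyl in place of hydrogen on an oxygen on a saturated carbon. Among the compounds with values here, compound 2 lies furthest off, its value beyond the scatter from that of compound 1, but no single-place step joins these two.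

Compound 4 `CCCCCCCCC(=O)O[C@H]1[C@H](O)[C@H](n2ccc(N)nc2=O)O[C@@H]1CO` is not yet measured. Its difference from compound 1: hydrogen in place of methyl on a saturated chain carbon, eight bonds along the chain from a carbonyl carbon. Within the data shown here, no measured step shortens or lengthens an acyl chain by one carbon; the only step at hand, from compound 1 to compound 3, adds an entire nonylcarbonyl and still stays within the scatter. No shift beyond the scatter is expected in either direction. Compound 4 is therefore estimated at 0.1 ug/mL (range 0.05 ug/mL to 0.2 ug/mL), an expected step of a 1.1-fold higher number from compound 1 to compound 4 (0.05 log units; within the scatter).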

Compound 4, concentration for half-maximal effect: 0.05 ug/mL
Beside the measured number, compound 4's estimate is 2.0-fold (0.30 log units) above it; the range from low to high includes it.
By their numbers in this assay, from the lowest: compounds 2, 4, 1 and 3 (each within the scatter of the next, the first and the last beyond it).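

In this assay, hydrogen in place of methyl on a saturated chain carbon, eight bonds along the chain from a carbonyl carbon, gives a 1.8-fold lower number from compound 1 to compound 4 (0.26 log units; within the scatter). Within the data shown here, this is the first reading of a change within the acyl chain itself, where earlier only a whole added nonylcarbonyl was compared, and at this place the change stays within the scatter. No measured evidence bears on why the number moves as it does. Still open, on these data alone, is whether an amine or a carboxylic acid in place of that methyl would stay within the scatter, and whether a much shorter chain, such as butyl, would do the same.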